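A few compounds are considered here, and "the series" means these few. Any claim that something is new, unique, unknown or untested is made for them only; others in the source may bear on it.

In a functional assay on a cell-free system (Platelet, plasma, Homo sapiens) for inhibition (on this read-out lower numbers stand for stronger inhibition and higher numbers for weaker inhibition), compound 2 (`COc1ccc(C(=O)N(CCN2CCC(OCC(=O)O)CC2)c2ccc(C)cc2)cc1`) gives 1200 nM, within the scatter of compound 1 (`Cc1ccc(N(CCN2CCC(OCC(=O)O)CC2)C(=O)c2ccc(Cl)cc2)cc1`) at 690 nM. Compound 3 (`Cc1ccc(N(CCN2CCC(OCC(=O)O)CC2)C(=O)c2ccc(-c3ccccc3)cc2)cc1`) reads > 10000 nM, which is a limit of the assay. Compound 4 (`Cc1ccc(N(CCN2CCC(OCC(=O)O)CC2)C(=O)c2cccc(F)c2)cc1`) has 3-fluorophenyl in place of 4-methoxyphenyl on a carbonyl carbon. Among the measured compounds shown here, three measured steps bear on this. Phenyl in place of chloro gave an at least 14-fold higher number from compound 1 to compound 3 (1.16 log units; beyond the scatter), and phenyl in place of methoxy gave an at least 8.3-fold higher number from compound 2 to compound 3 (0.92 log units; beyond the scatter). For the measured compounds named here, the entering group holds only one ring, so the closer guide is methoxy in place of chloro, which gave a 1.7-fold higher number from compound 1 to compound 2 (0.24 log units; within the scatter), and no change beyond the scatter is expected. The expected step is a 1.2-fold lower number from compound 2 to compound 4 (0.08 log units; within the scatter). Compound 4 is estimated at 1000 nM, with an expected range of 350 nM to 3500 nM.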

Compound 4, half-maximal inhibitory concentration: 160 nM
Compound 4: middle estimate off by 6.3-fold (0.80 log units), on the high side, and the stated range ends above it.
By their numbers in this assay, from the lowest: compound 4; then compounds 1 and 2 (each within the scatter of the next). At a limit, above all of these: compound 3.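

On the carbonyl carbon, single-ring groups are not interchangeable: 3-fluorophenyl in place of 4-methoxyphenyl gave a 7.5-fold lower number from compound 2 to compound 4 (0.88 log units; beyond the scatter), and 3-fluorophenyl in place of 4-chlorophenyl gave a 4.3-fold lower number from compound 1 to compound 4 (0.63 log units; beyond the scatter). Compounds 1 and 2 alone, within the scatter of each other, did not show this room for stronger inhibition. Nothing shown gives a cause for this change.

On these data alone, both steps alter the ring substituent and its place together, so it stays open which of the two matters. 4-Fluorophenyl, 3-chlorophenyl and 3-methoxyphenyl on the same carbonyl carbon would separate them.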